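Pyrazolopyrimidinone series: swapping the pyrazole nitrogen aryl group

The source may hold more compounds than are shown below. What is called first, only, known or untested is meant among the compounds shown, and "the series" means these compounds.

Working notes on the series. Compound 1 `Cc1nc2c(cnn2-c2ccccc2)c(=O)n1C1CCCCCC1` carries a cycloheptyl group and a phenyl group on its core; in an in vitro functional assay on cells for antagonist activity at metabotropic glutamate receptor 5 (Homo sapiens), read by FLIPR and calcium flux (a higher number here means a weaker inhibitor, a lower number a stronger inhibitor), the entry for compound 1 reads "not determined" (no result reported), so it contributes no number. Compound 2 `Cc1ccccc1-n1ncc2c(=O)n(-c3ccc(Cl)cc3)c(C)nc21` is the only member with a figure: in this assay compound 2 gives 9500 nM, which places it as a weak inhibitor and as the sole reference point on the numbers shown, the other entry being without one.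

Compound 3 `Cc1nc2c(cnn2-c2cncnc2)c(=O)n1-c1ccc(Cl)cc1` differs from compound 2 in one place: pyrimidin-5-yl in place of 2-methylphenyl on an aromatic nitrogen. Among the measured compounds shown here, no step between two measured compounds exists for this or any other change, so the direction of the step must be taken from the shared core and the single value of compound 2 alone.

Given the weak starting point of compound 2 at 9500 nM, the expectation for compound 3 is a step of a 1.6-fold higher number from compound 2 to compound 3 (0.20 log units; within the scatter), not clearly beyond the scatter, if anything toward weaker inhibition. Compound 3 is therefore estimated at 15000 nM in this assay, with a range from 4000 nM to 50000 nM.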

Compound 3, half-maximal inhibitory concentration: > 100000 nM
Compound 3: only a limit was reported (the forecaster's own chance of this, stated with the estimate: 35%); middle value at least 6.6-fold (0.82 log units) away from the limit.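

Pyrimidin-5-yl in place of 2-methylphenyl on an aromatic nitrogen gives, in this assay, an at least 10-fold higher number from compound 2 to compound 3 (1.02 log units; beyond the scatter), the first readable step in the series and one that lies beyond the scatter. With only the single value of the earlier compounds to go on, nothing had shown whether this place on the shared core affected the read-out at all; this change alone, with the rest of the structure held constant, shows that it does, and that the already weak activity can fall further. The entry for compound 3 is a limit and not a number: the limit of > 100000 nM in this assay, at which 1 of the 3 values shown sits.

What remains open is which part of the change carries the step, as the swap removes the methyl group and brings in the ring nitrogens in a single move, and the compounds shown offer no intermediate case. A pyridin-3-yl or a 2-chlorophenyl group at this place would bear on that question, and whether any group here gives stronger inhibition than compound 2 also stays unanswered.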